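The source may report more compounds than this note shows. Statements on the series, on what has been measured and on what is new or still open speak of the compounds shown alone.

Two compounds have been measured in a functional assay on cells (Panel breast (Carcinoma cell lines), Homo sapiens) for inhibition, read by sulforhodamine B assay, with a stated time of 48 h; a higher number here means a weaker inhibitor of growth, a lower number a stronger inhibitor of growth:
compound 1 `CN1CCN(CCCOc2cccc3nc(Nc4ccc(F)c(F)c4)ccc23)CC1` gives 7980 nM;
compound 2 `CN1CCN(CCCOc2cccc3nc(Nc4cc(Cl)cc(Cl)c4)ccc23)CC1` gives 5670 nM.

On these two numbers compound 2 holds the lower value, but the step of a 1.4-fold lower number from compound 1 to compound 2 (0.15 log units; within the scatter) is within the scatter, so no order between the two can be claimed. Compound 3 `CN1CCN(CCCOc2cccc3nc(Nc4cccc(Cl)c4)ccc23)CC1` has not yet been measured. It differs from compound 2 by hydrogen in place of chloro on an aromatic carbon. Among the measured compounds shown here, the only measured step, from compound 1 to compound 2, alters the halogen pattern on the same ring in a different way and was itself within the scatter, so it offers no direct precedent for removing a single chloro. The change is therefore expected to leave the number near that of compound 2, if anything slightly higher. Compound 3 is estimated at 7500 nM in this assay, with a range from 3000 nM to 18000 nM, a step of a 1.3-fold higher number from compound 2 to compound 3 (0.12 log units; within the scatter).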

Compound 3, concentration for total growth inhibition: 6690 nM
Beside the measured number, compound 3's estimate is 1.1-fold (0.05 log units) above it; measured number inside the range.
By their numbers in this assay, from the lowest: compounds 2, 3 and 1 (each within the scatter of the next).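

Going from 3,5-dichlorophenyl to 3-chlorophenyl in this assay gives a 1.2-fold higher number from compound 2 to compound 3 (0.07 log units; within the scatter) and so shows that, in this series, taking away one chloro from this ring has no effect that can be told from the scatter. The 3,4-difluorophenyl and 3-chlorophenyl compounds also stay close, with a 1.2-fold lower number from compound 1 to compound 3 (0.08 log units; within the scatter) as their step, so the three halogen patterns shown cannot be put in any order. No measurement at hand offers an explanation for these small steps.

The compounds shown leave open whether an unsubstituted phenyl, with no halogen at all, would stay within the same narrow band of values. As far as these compounds go, it also remains open whether a methoxy group, a trifluoromethyl or an amine on this ring would give a larger step.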